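Swapping the acyl warhead on a trimethoxyphenyl amide

The source may report more compounds than this note shows. Statements on the series, on what has been measured and on what is new or still open speak of the compounds shown alone.

Three compounds anchor this account. Within the data shown here, compound 1 `C/C=C/C(=O)N(Cc1ccc(OC)c([N+](=O)[O-])c1)c1cc(OC)c(OC)c(OC)c1` gives 510 nM in a functional assay on KYSE-450 cells (Homo sapiens) for inhibition, read by MTT assay, with a stated time of 48 h (a lower number here means a stronger inhibitor, a higher number a weaker inhibitor), while compound 3 `C/C=C/C(=O)N(Cc1ccc(OC)c(OC)c1)c1cc(OC)c(OC)c(OC)c1` gives 39100 nM, the only one-place step measured being a 77-fold higher number from compound 1 to compound 3 (1.88 log units; beyond the scatter). Compound 2 `COc1ccc(CN(C(=O)C(C)Br)c2cc(OC)c(OC)c(OC)c2)cc1O` gives 160 nM and stands lowest of the three. Compound 4 `C=CC(=O)N(Cc1ccc(OC)c(O)c1)c1cc(OC)c(OC)c(OC)c1` keeps the core of compound 2 and differs only at the carbonyl carbon: vinyl in place of 1-bromoethyl on a carbonyl carbon. Among the measured compounds shown here, no measured step touches this position, so the expectation rests on compound 2 alone and is wide. A modest shift toward a higher number, a 1.9-fold higher number from compound 2 to compound 4 (0.27 log units; within the scatter), is expected, and compound 4 is therefore estimated at 300 nM, between 80 nM and 1200 nM.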

Compound 4, half-maximal inhibitory concentration: 160 nM
Beside the measured number, compound 4's estimate is 1.9-fold (0.27 log units) above it; the measured number falls inside the stated range.
By their numbers in this assay, from the lowest: compounds 2 and 4 (each within the scatter of the next); then compound 1; then compound 3.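

In this assay the position on the carbonyl carbon now has its first measured step, no change at the digits printed from compound 2 to compound 4 (within the scatter). On the core shared by these two compounds, vinyl and 1-bromoethyl therefore cannot be told apart, even though the bromine leaves and a double bond enters. Nothing available explains why the two groups read alike. Open, going by these compounds, is whether an ethyl group, which carries neither the bromine nor the double bond, would read the same on this carbonyl carbon. Also open, on these data alone, is whether the swap would hold on the core of compound 1.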